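The source may hold more compounds than are shown below. What is called first, only, known or untested is meant among the compounds shown, and "the series" means these compounds.

Measured compounds:
compound 1, `O=C(c1ccc(OC(F)(F)F)cc1)N1CCC(N(C2CC2)S(=O)(=O)c2cccc(C(F)(F)F)c2)CC1`, in an assay on cells for inhibition of Voltage-dependent L-type calcium channel subunit alpha-1C (Homo sapiens), read by FLIPR and calcium flux, tested at 1 uM (a lower number here means a weaker effect, a higher number a stronger effect of the compound at the concentration tested), compound 1 gives 73%.
compound 2, `CS(=O)(=O)c1cccc(C(=O)N2CCC(N(C3CC3)S(=O)(=O)c3cccc(C(F)(F)F)c3)CC2)c1`, in this assay compound 2 gives "not determined" (no result reported).

Compound 2 stands nowhere on the numbers shown: no figure exists for it in this assay, so its place relative to compound 1 cannot be told, and only compound 1 offers an anchor for this series. The change to compound 3, `CS(=O)(=O)c1ccc(F)cc1C(=O)N1CCC(N(C2CC2)S(=O)(=O)c2cccc(C(F)(F)F)c2)CC1`, is 5-fluoro-2-(methylsulfonyl)phenyl in place of 3-(methylsulfonyl)phenyl on a carbonyl carbon. For the measured compounds named here, as no step between measured compounds is given, the size of this step in this assay cannot be derived from the data; since compound 1, carrying a different group on the same carbonyl carbon, gives a clear inhibition, a result of comparable order for compound 3 is conceivable, but the direction from compound 2 remains open and the expected step is taken as none beyond the scatter. Compound 3 is accordingly expected to reach about 50% in this assay, within an estimated range from 15% to 85%.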

Compound 3, a percentage reported as inhibition, at one concentration (the size of the read-out at that concentration, not a potency): 18%
Estimate against measurement, compound 3: 32 percentage points above; measured number inside the range.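

In this assay, for the compounds shown here, putting 5-fluoro-2-(methylsulfonyl)phenyl in place of 4-(trifluoromethoxy)phenyl on the carbonyl carbon gives a number 55 percentage points lower from compound 1 to compound 3 (beyond the scatter), the first readable comparison, and it shows that the group at this place can move the read-out well beyond the scatter while the rest of the molecule stays the same. As far as these compounds go, the step from compound 2 to compound 3 cannot be read, so the contribution of the added fluorine and of the changed place of the methylsulfonyl group remains unknown. Nothing shown gives a measured reason for the lower inhibition.

The compounds shown leave open which feature of the two aryl groups sets the difference between compound 1 and compound 3. They also leave open how an unsubstituted phenyl, or a phenyl carrying a carboxylic acid, would read on the same carbonyl carbon.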